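The source may report more compounds than this note shows. Statements on the series, on what has been measured and on what is new or still open speak of the compounds shown alone.

Of the compounds shown here, three built on one shared core have been measured in an ADME assay on BaF3 cells (Mus musculus) for antiproliferative activity; a lower number here means a stronger inhibitor of growth, a higher number a weaker inhibitor of growth. Compound 1 `Cc1ccc(NC(=O)c2cccc(C(F)(F)F)c2)cc1OCCNC(=O)c1cccnc1` gives > 10000 nM, which is a limit of the assay and not a number. Compound 2 `Cc1ccc(NC(=O)c2cccc(C(F)(F)F)c2)cc1OCCNC(=O)c1ccno1` gives > 10000 nM, again a limit. Compound 3 `Cc1ccc(NC(=O)c2cccc(C(F)(F)F)c2)cc1OC1CCN(C(=O)c2cccnc2)CC1` gives > 10000 nM, likewise a limit. Going by the values given here, the one step between measured compounds that differ in a single place, a step that the two limits leave unreadable from compound 1 to compound 2, cannot be read because both of its ends are limits. Among the compounds with values here, compound 3 therefore stands at the limit of > 10000 nM in this assay, at which 3 of the 3 values shown sit, and no measured compound in this set gives a number to set against it.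

Compound 4 `Cc1ccc(NC(=O)c2cccc(C(F)(F)F)c2)cc1OC1CCN(C(=O)c2ccccn2)CC1` has not yet been measured. It differs from compound 3 in one place: pyridin-2-yl in place of pyridin-3-yl on a carbonyl carbon. No measured step follows a change of this kind, and the only step shown is unreadable, so nothing here gives grounds for expecting a step beyond the scatter in either direction. Compound 4 is thus expected to sit at the limit as well, with an estimated value of 12000 nM and a range from 3000 nM to 50000 nM. The step this estimate means is a step that the limit leaves unreadable from compound 3 to compound 4, expected to be no more than the scatter.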

Compound 4, concentration for 50% growth inhibition: > 10000 nM
Compound 4: no number, only a limit; the forecaster's own chance of this, stated with the estimate: 85%; the middle value lies beyond the limit too.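

Compound 4 gives > 10000 nM in this assay and this is a limit of the assay, not a number. Going by these compounds alone, compound 3 also stands at a limit, so no step between the two can be read. The compounds shown leave open which change to the shared core, if any, would give a measurable number.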